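The source may hold more compounds than are shown below. What is called first, only, known or untested is meant among the compounds shown, and "the series" means these compounds.

In a physicochemical assay for solubility, read by HPLC, in simulated intestinal fluid, with a stated time of 16 h, tested at 125 ug/mL (a lower number here means a less soluble compound, a higher number a more soluble compound), compound 1 (`CNC(=O)c1cc(C(=O)NC2CCC2)cn(Cc2ccccn2)c1=O`) gives 920 ug/mL, the highest of the three numbers and beyond the scatter of the other two. Compound 2 (`CNC(=O)c1cc(C(=O)NC2CC2)cn(Cc2cccc(C)c2)c1=O`) gives 88 ug/mL, and compound 3 (`CNC(=O)c1cc(C(=O)NC2CC2)cn(Cc2cccc3cn[nH]c23)c1=O`) gives 131 ug/mL. Compound 4 (`CNC(=O)c1cc(C(=O)NC2CCC2)cn(Cc2cccnc2)c1=O`) differs from compound 1 in one place: pyridin-3-yl in place of pyridin-2-yl on a saturated chain carbon bound to an aromatic nitrogen. For the measured compounds named here, only one measured step changes the group at this place, a 1.5-fold higher number from compound 2 to compound 3 (0.17 log units; within the scatter), and it involves other groups and another amide, so it is a loose guide. Going by the values given here, no measured step exchanges pyridin-2-yl for pyridin-3-yl. No change beyond the scatter is therefore expected in this assay. The estimated step is a 1.2-fold lower number from compound 1 to compound 4 (0.09 log units; within the scatter). Compound 4 is expected at 750 ug/mL, with an estimated range of 350 ug/mL to 1300 ug/mL.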

Compound 4, solubility: 189 ug/mL
For compound 4 the middle estimate is 4.0-fold (0.60 log units) above the measured one; measured number below the stated range.
By their numbers in this assay, from the lowest: compounds 2, 3 and 4 (each within the scatter of the next, the first and the last beyond it); then compound 1.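

Exchanging pyridin-2-yl for pyridin-3-yl on a saturated chain carbon bound to an aromatic nitrogen gives a 4.9-fold lower number from compound 1 to compound 4 (0.69 log units; beyond the scatter) in this assay even though the two groups match in every count of atoms, donors and acceptors. This place therefore responds to which pyridine isomer it carries, not only to the group's composition. No measurement on hand accounts for the gap.

Pyridin-4-yl at this place would show whether compound 1 or compound 4 is the outlier among the pyridines. A longer chain carrying pyridin-2-yl would test how far the higher reading of compound 1 persists.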